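Aryl amide exchange on a shared core

This account rests on a few compounds, and the source may have more. Where it says the series, first, only, none or still open, it means among the compounds named here.

In an assay on HEK293 cells for agonist activity at Bile acid receptor (Homo sapiens), read by a luciferase reporter (on this read-out higher numbers stand for an effect only at larger amounts of compound and lower numbers for an effect already at smaller amounts), compound 1 `CC(C)OC(=O)C1=CN(C(=O)c2ccc(F)cc2)CC(C)(C)c2cc(C#N)[nH]c21` gives 5 nM, compound 2 `CC(C)OC(=O)C1=CN(C(=O)c2cccc(C(F)(F)F)c2)CC(C)(C)c2cc(C#N)[nH]c21` gives 8.5 nM, and compound 3 `CC(C)OC(=O)C1=CN(C(=O)c2ccc(F)c(F)c2)CC(C)(C)c2cc(C#N)[nH]c21` gives 6.3 nM. Compound 3 stands second highest of these three numbers; its nearest is compound 1, its furthest is compound 2, and both gaps lie within the scatter. Compound 4 `CC(C)OC(=O)C1=CN(C(=O)c2cccc(Cl)c2)CC(C)(C)c2cc(C#N)[nH]c21` differs from compound 3 by 3-chlorophenyl in place of 3,4-difluorophenyl on a carbonyl carbon. The earlier exchanges at the same carbonyl carbon bear on this: a 1.7-fold higher number from compound 1 to compound 2 (0.23 log units; within the scatter) and a 1.3-fold lower number from compound 2 to compound 3 (0.13 log units; within the scatter), both within the scatter, as is a 1.3-fold higher number from compound 1 to compound 3 (0.10 log units; within the scatter). No aryl exchange so far has moved this assay beyond the scatter. Compound 4 is therefore expected to give 7 nM, with a range from 3 nM to 16 nM. The expected step is a 1.1-fold higher number from compound 3 to compound 4 (0.05 log units; within the scatter), nothing beyond the scatter.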

Compound 4, half-maximal effective concentration: 12 nM
Compound 4: the middle estimate sits 1.7-fold (0.23 log units) below what was measured, within the range that was stated.
By their numbers in this assay, from the lowest: compounds 1, 3, 2 and 4 (each within the scatter of the next, the first and the last beyond it).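

In this assay, an aryl exchange at this carbonyl carbon now gives its first step beyond the scatter, a 2.4-fold higher number from compound 1 to compound 4 (0.38 log units; beyond the scatter), with 3-chlorophenyl in place of 4-fluorophenyl. For the compounds shown here, the other two exchanges that lead to the chloro compound stay within the scatter, a 1.9-fold higher number from compound 3 to compound 4 (0.28 log units; within the scatter) and a 1.4-fold higher number from compound 2 to compound 4 (0.15 log units; within the scatter), so only one pair among the four aryl amides separates. Nothing measured here explains that step. The compounds shown leave open whether an amine or a carboxylic acid on the phenyl ring, in place of the chloro, fluoro or trifluoromethyl groups, would move the number beyond the scatter of all four compounds.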